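Swapping the five-membered ring on the piperazine arm

The compounds below may be only part of what the source reports. "The series", "measured", "known", "first", "only" and "open" are said of these compounds alone.

Measured so far:
compound 1, `Cc1nc(C)c(CN2CCN(c3cccc4[nH]c(-c5ccc(C(C)(C)C)cc5)nc34)CC2)o1`, 31 nM
compound 2, `CCc1nc(C)c(CN2CCN(c3cccc4[nH]c(-c5ccc(C(C)(C)C)cc5)nc34)CC2)s1`, 20 nM
compound 3, `Cc1cc(CN2CCN(c3cccc4[nH]c(-c5ccc(C(C)(C)C)cc5)nc34)CC2)nn1C`, 83 nM

These three share one core and differ only in the small aromatic ring carried on a saturated chain carbon bound to an amine nitrogen in a ring. In an assay on isolated protein for displacement of a labelled ligand from Gonadotropin-releasing hormone receptor (Homo sapiens) (a lower number here means a stronger inhibitor, a higher number a weaker inhibitor), compound 3 has the highest number of the three: a 2.7-fold higher number from compound 1 to compound 3 (0.43 log units; beyond the scatter) and a 4.2-fold higher number from compound 2 to compound 3 (0.62 log units; beyond the scatter), both modest but beyond the scatter, so compound 3 is the weakest of the measured set. Between compound 1 and compound 2 the step is a 1.6-fold lower number from compound 1 to compound 2 (0.19 log units; within the scatter), within the scatter.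

Compound 4, `CCCn1cnc(CN2CCN(c3cccc4[nH]c(-c5ccc(C(C)(C)C)cc5)nc34)CC2)c1C`, is not yet measured. Within the data shown here, it changes only that ring: 5-methyl-1-propyl-1H-imidazol-4-yl in place of 1,5-dimethyl-1H-pyrazol-3-yl on a saturated chain carbon bound to an amine nitrogen in a ring.

The two steps that bear on this change are those into compound 3, where each exchange of one five-membered ring for another moved the number by a modest amount. The exchange here is of the same kind, so a modest step is expected for compound 4 in this assay, most plausibly towards a lower number, though a step within the scatter cannot be excluded. Compound 4 is estimated at 45 nM, with a range of 12 nM to 160 nM, which means an expected step of a 1.8-fold lower number from compound 3 to compound 4 (0.27 log units; within the scatter).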

Compound 4, half-maximal inhibitory concentration: 12 nM
For compound 4 the middle estimate is 3.8-fold (0.57 log units) above the measured one; measured number inside the range.
By their numbers in this assay, from the lowest: compounds 4, 2 and 1 (each within the scatter of the next, the first and the last beyond it); then compound 3.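

In this assay, putting 5-methyl-1-propyl-1H-imidazol-4-yl in place of 1,5-dimethyl-1H-pyrazol-3-yl gives a 6.9-fold lower number from compound 3 to compound 4 (0.84 log units; beyond the scatter) and is the widest step in this set. Both rings carry two nitrogens and the same counts of hydrogen-bond donors and acceptors, so those counts alone do not settle the number at this position, and nothing measured here accounts for the difference.

The new group also compares well with the other two rings, with a 2.6-fold lower number from compound 1 to compound 4 (0.41 log units; beyond the scatter) and a 1.7-fold lower number from compound 2 to compound 4 (0.22 log units; within the scatter) showing that a ring bearing a propyl chain is accepted on this saturated chain carbon and that compound 3 alone stands apart as the weakest of the four.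

Compound 4 differs from compound 3 both in the ring and in its propyl chain, so the compounds shown do not separate the share of each in the step. They also leave open how far this position accepts further growth, for example a butyl chain in place of the propyl, or a chain ending in an amine or a carboxylic acid.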